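Swapping Methoxy for Fluoro on a Shared Core

The compounds below may be only part of what the source reports. "The series", "measured", "known", "first", "only" and "open" are said of these compounds alone.

Three compounds share one core and differ only in the group attached to it. In a functional assay on SF-539 cells (Homo sapiens) for inhibition, read by sulforhodamine B assay, with a stated time of 48 h (a lower number here means a stronger inhibitor of growth, a higher number a weaker inhibitor of growth), compound 1 `CCOC(=O)[C@H](CCC(=O)O)NC(=O)c1ccc(CNc2nc3cc(N)cc(N)c3nc2-c2ccccc2)cc1` reaches only the assay limit, < 100000 nM. Compound 2 `COc1ccc(CNc2nc3cc(N)cc(N)c3nc2-c2ccccc2)cc1OC` gives 20000 nM in this assay. Compound 3 `COc1ccc(Sc2nc3cc(N)cc(N)c3nc2-c2ccccc2)cc1` gives 10000 nM in this assay, and this value and that of compound 2 lie within the usual scatter of each other. Compound 4 `Nc1cc(N)c2nc(-c3ccccc3)c(Sc3ccc(F)cc3)nc2c1` has not yet been measured. It differs from compound 3 by fluoro in place of methoxy on an aromatic carbon. Among the measured compounds shown here, no measured pair of compounds shows this change, so no size or direction can be read from the data. The step of no change at the digits printed from compound 3 to compound 4 (within the scatter) is therefore expected to stay within the scatter. Compound 4 is expected to give about 10000 nM in this assay, between 3000 nM and 35000 nM.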

Compound 4, concentration for 50% growth inhibition: 21400 nM
The estimate for compound 4 lay 2.1-fold (0.33 log units) below the measured number; the measured number falls inside the stated range.
By their numbers in this assay, from the lowest: compounds 3, 2 and 4 (each within the scatter of the next, the first and the last beyond it).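

Among the compounds shown here, compounds 3 and 4 form the only pair here that differs in one place, so they give the first direct reading of a change on this aromatic carbon, para to a large group. In this assay, fluoro in place of methoxy gives a 2.1-fold higher number from compound 3 to compound 4 (0.33 log units; beyond the scatter), which shows that this position is not indifferent to the group it carries, though the effect is small. Nothing shown here explains the step.

As far as these compounds go, how an amine or a carboxylic acid at this position would read remains open. So does whether the same swap would move the number the same way on the compounds with a nitrogen link.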